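A second fluoro-for-hydrogen step on a different core

The compounds below may be only part of what the source reports. "The series", "measured", "known", "first", "only" and "open" are said of these compounds alone.

The study concerns four benzotriazole-bearing compounds examined in an ADME assay on microsomes from liver (Rattus norvegicus, strain Wistar) for metabolic stability, tested at 2.5 uM; a higher number here means faster removal of the compound, a lower number slower removal. Compound 1 `Fc1cc(Cl)ccc1-c1ccc(Cn2nnc3ccccc32)cn1` gives 0.8 mL/min/g in this assay. Compound 2 `Fc1ccc2c(c1)nnn2Cc1ccc(-c2ccc(Cl)cc2F)nc1` carries a single added fluorine on the core of compound 1, a change counted as fluoro in place of hydrogen on an aromatic carbon, and in this assay compound 2 gives 0.5 mL/min/g. The measured step is a 1.6-fold lower number from compound 1 to compound 2 (0.20 log units; within the scatter).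

Compound 3 `Clc1ccc(Cn2nnc3c(Br)cccc32)cc1` has a different core; how its core differs from that of compound 1 is not broken down here. In this assay compound 3 gives 2.2 mL/min/g, the highest of the three numbers, beyond the scatter from both compound 1 and compound 2.

Compound 4 `Fc1cc(Cn2nnc3c(Br)cccc32)ccc1Cl` has not yet been measured. It differs from compound 3 by fluoro in place of hydrogen on an aromatic carbon. For the measured compounds named here, this is the same kind of change as the one from compound 1 to compound 2, but the surroundings differ: in compound 2 the new fluorine sits on an aromatic carbon of a six-membered aromatic ring of carbon only, part of a fused or bridged system of two rings, meta to a fused ring and para to a fused ring, whereas in compound 4 it sits on an aromatic carbon of a six-membered aromatic ring of carbon only, ortho to a chloro group and meta to a large group.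

The expected step is a 1.2-fold lower number from compound 3 to compound 4 (0.09 log units; within the scatter), which rests on the earlier step of a 1.6-fold lower number from compound 1 to compound 2 (0.20 log units; within the scatter) that stayed within the scatter. Compound 4 is therefore estimated to give 1.8 mL/min/g in this assay, with a range from 0.9 mL/min/g to 3.6 mL/min/g.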

Compound 4, intrinsic clearance in a liver preparation (reported as CLH), per the amount of preparation that the assay uses: 3.1 mL/min/g
Compound 4: the middle estimate sits 1.7-fold (0.24 log units) below what was measured; the measured number falls inside the stated range.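

In this assay the exchange of hydrogen for fluoro on an aromatic carbon comes to a 1.4-fold higher number from compound 3 to compound 4 (0.15 log units; within the scatter), so on this second core, as on the first, the change leaves the number within the usual scatter of the measurement. Set beside each other, the two steps cannot be told apart: the same change on two cores in this assay, a 1.6-fold lower number (0.20 log units; within the scatter) from compound 1 to compound 2 and a 1.4-fold higher number (0.15 log units; within the scatter) from compound 3 to compound 4, 2.3-fold (0.35 log units) apart, within the scatter of two such steps. This shows that in these two pairs the single added fluorine carries over without a step beyond the scatter, but it does not show that the change is without effect elsewhere in the series, and it cannot separate the role of the core from that of the place, since in compound 4 the fluorine sits ortho to a chloro group while in compound 2 it sits on the fused system.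

Fluoro is the only group that enters in these pairs, so it remains open whether a methoxy group, a nitrile or a trifluoromethyl group on the same carbon of compound 3 would move the number beyond the scatter. As far as these compounds go, it also remains open how the number in this assay would respond if the bromo group of compound 4 gave way to a methyl group or an amine.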